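From Compound 1 to Compound 3 on Breast Cancer Cells

This account rests on a few compounds, and the source may have more. Where it says the series, first, only, none or still open, it means among the compounds named here.

compound 1 `COc1cc(-c2ccnc3cc(-c4ccc(C(C)(C)C)cc4)nn23)cc(OC)c1OC` — > 10000 nM
compound 2 `COc1cc(-c2cc3nccc(-c4c[nH]c5ccccc45)n3n2)cc(OC)c1OC` — > 10000 nM

In a functional assay on MCF7 cells (Homo sapiens) for inhibition, read by CCK-8 assay, with a stated time of 48 h (on this read-out higher numbers stand for weaker inhibition and lower numbers for stronger inhibition), compound 1 gives > 10000 nM, which is a limit of the assay and not a number. Compound 2 gives > 10000 nM, likewise a limit. Compound 1 therefore stands at the limit of > 10000 nM in this assay, at which 2 of the 2 values shown sit, and no order between the two can be read. Compound 3 `COc1cc(-c2ccnc3cc(-c4ccc5cnn(C)c5c4)nn23)cc(OC)c1OC` differs from compound 1 by 1-methyl-1H-indazol-6-yl in place of 4-(tert-butyl)phenyl on an aromatic carbon. Among the compounds with values here, no step between measured compounds is available to calibrate this change. Compound 3 is expected to remain weak, with an estimated step of an at least 1.2-fold lower number from compound 1 to compound 3 (0.09 log units; that floor lies within the scatter) not beyond the scatter. Compound 3 is estimated at 8000 nM, in the range 1500 nM to 30000 nM.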

Compound 3, half-maximal inhibitory concentration: 279 nM
Compound 3: the middle estimate sits 29-fold (1.46 log units) above what was measured; measured number outside the range, below it.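

In this assay, this position on the five-membered aromatic ring proves able to carry a large change: 1-methyl-1H-indazol-6-yl in place of 4-(tert-butyl)phenyl gives an at least 35-fold lower number from compound 1 to compound 3 (1.55 log units; beyond the scatter). The size of this step is only a lower bound, and compound 3 is the only compound shown that lies clear of the limit: the limit of > 10000 nM in this assay, at which 2 of the 3 values shown sit.

The compounds shown leave open whether the step follows the two ring nitrogens, the second ring or the methyl, as all of these enter together. As far as these compounds go, whether a phenyl bearing an amine would hold the value also remains open.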